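Methylamino for Methoxy on the Seven-Membered Aromatic Ring

The compounds below may be only part of what the source reports. "The series", "measured", "known", "first", "only" and "open" are said of these compounds alone.

Compound 2 `CCOC(=O)C(=O)Nc1ccccc(OC)c1=O` has been measured in a functional assay on the whole organism (strain Sprague-Dawley CD) for inhibition, with Rattus norvegicus as the target, read by paw edema, at a dose of 30 mg/kg by the intraperitoneal route (on this read-out lower numbers stand for a weaker effect and higher numbers for a stronger effect at the one dose given), where compound 2 gives 52%. Its nearest neighbour, compound 1 `CCOC(=O)C(=O)Nc1ccccc(Br)c1=O`, in this assay gives 52%, so the two stand level, the step being no change at the digits printed from compound 1 to compound 2 (within the scatter). Compound 3 `CCOC(=O)C(=O)Nc1ccccc(NC)c1=O` is not yet measured. It differs from compound 2 by methylamino in place of methoxy on an aromatic carbon. Among the compounds with values here, the only measured step that bears on this change is no change at the digits printed from compound 1 to compound 2 (within the scatter): exchanging one group for another on an aromatic carbon left the read-out where it was. Within the data shown here, no other step is known for this place on the ring, and nothing in the numbers points up or down. Compound 3 is therefore expected to stay close to compound 2, with an estimated step of a number 2 percentage points lower from compound 2 to compound 3 (within the scatter) that should not exceed the scatter. The estimate for compound 3 in this assay is 50%, within a range from 35% to 65%.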

Compound 3, a percentage reported as inhibition, in the whole organism at one dose (the size of the read-out at that dose, not a potency): 83%
The estimate for compound 3 lay 33 percentage points below the measured number; the measured number lies above the stated range.
By their numbers in this assay, from the lowest: compounds 1 and 2 (each within the scatter of the next); then compound 3.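

Within the data shown here, until now the only exchange at this place, between bromo and methoxy, had left the read-out unmoved, so the place looked indifferent to the group it carries. In this assay that no longer holds: methylamino in place of methoxy (a number 31 percentage points higher from compound 2 to compound 3 (beyond the scatter)) and methylamino in place of bromo (a number 31 percentage points higher from compound 1 to compound 3 (beyond the scatter)) both raise the effect at the one dose given, so this aromatic carbon does respond to its group. Nothing at hand explains the rise.

Whether the gain extends to other nitrogen groups stays open: the compounds shown do not tell how an unsubstituted amine, dimethylamino or the longer ethylamino would read at this place. As far as these compounds go, it also stays open how the compounds compare at other doses, as the read-out gives the size of the effect at one dose only.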